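This account rests on a few compounds, and the source may have more. Where it says the series, first, only, none or still open, it means among the compounds named here.

Of the compounds shown here, three sharing one core have been tested in a functional assay on the whole organism (Tail, strain ICR) with Mus musculus as the target, in the tail flick test, with a stated time of 90 min, at a dose of 25 umol/kg by the oral route; on this read-out higher numbers stand for a stronger effect at the one dose given and lower numbers for a weaker effect. Compound 1 `N=C(N)NCCC[C@H](NC(=O)CN(c1nc(Cl)nc2[nH]cnc12)C1CC1)C(=O)OCc1ccccc1` gives 30.4% in this assay, compound 2 `NC(=O)C[C@H](NC(=O)CN(c1nc(Cl)nc2[nH]cnc12)C1CC1)C(=O)O` gives 20.1%, and compound 3 `C[C@@H](O)[C@H](NC(=O)CN(c1ncnc2c1ncn2C1CCCCO1)C1CC1)C(=O)OCc1ccccc1` gives 23.4%. These three numbers lie close together: compound 3 differs from compound 2 and from compound 1 only by amounts within the usual scatter, so no order among them can be read. Compound 4 `CC(C)[C@H](NC(=O)CN(c1ncnc2c1ncn2C1CCCCO1)C1CC1)C(=O)OCc1ccccc1` has not yet been measured and differs from compound 3 in one place: isopropyl in place of 1-hydroxyethyl on a saturated chain carbon bound to an amide-type nitrogen and a carbonyl carbon. Within the data shown here, no measured pair differs in the same way, so the data give no guide to this change. The expected step is a number 0.4 percentage points lower from compound 3 to compound 4 (within the scatter), which lies within the scatter. Compound 4 is therefore estimated at 23%, with a range from 10% to 38%.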

Compound 4, a percentage reported as activity, at one dose (the size of the read-out at that dose, not a potency): 30.1%
Estimate against measurement, compound 4: 7.1 percentage points below; measured number inside the range.
By their numbers in this assay, from the lowest: compounds 2, 3, 4 and 1 (each within the scatter of the next, the first and the last beyond it).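

In this assay, isopropyl in place of 1-hydroxyethyl on this saturated chain carbon gives a number 6.7 percentage points higher from compound 3 to compound 4 (within the scatter) and so shows no clear change. At this one dose, the position therefore carries a side chain with a hydroxyl or an all-carbon branched one without a step beyond the scatter. No measurement shown gives a reason for this result.

From the compounds shown here alone, whether an amine, a carboxylic acid or a longer chain at this carbon would change the read-out remains open. A single dose also leaves the potency of both compounds open.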